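Dichlorophenyl in place of fluorophenyl on the sulfonyl sulfur

The compounds below may be only part of what the source reports. "The series", "measured", "known", "first", "only" and "open" are said of these compounds alone.

In an ADME assay on HEK293 cells (Homo sapiens) for cytotoxicity, read by resazurin assay, with a stated time of 48 h (on this read-out lower numbers stand for higher toxicity in this test and higher numbers for lower toxicity in this test), compound 1 `O=S(=O)(Nc1ccc(-c2nc3ccccc3o2)cc1)c1ccc(O)cc1` gives > 100000 nM as a limit of the assay, not a number. Compound 2 `O=S(=O)(Nc1ccc(-c2nc3ccccc3o2)cc1)c1ccc(F)cc1` gives > 100000 nM as a limit too, so its standing has no readable number behind it. The next change puts 3,4-dichlorophenyl in place of 4-fluorophenyl on a sulfonyl sulfur and gives compound 3 `O=S(=O)(Nc1ccc(-c2nc3ccccc3o2)cc1)c1ccc(Cl)c(Cl)c1` (3,4-dichlorophenyl in place of 4-fluorophenyl on a sulfonyl sulfur). Going by the values given here, the single measured step that the two limits leave unreadable from compound 1 to compound 2 has no readable size, and the limit of > 100000 nM in this assay, at which 2 of the 2 values shown sit, is all the series offers so far. Compound 3 is therefore expected to stay close to that limit, with any readable step in this assay running toward lower numbers, meaning higher toxicity. The expected step is an at least 1.6-fold lower number from compound 2 to compound 3 (0.22 log units; that floor lies within the scatter) at most a modest one. For compound 3 the estimate is 60000 nM with 15000 nM to 100000 nM as the expected range.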

Compound 3, half-maximal cytotoxic concentration: > 100000 nM
Compound 3 ended at the assay's limit (the forecaster's own chance of this, stated with the estimate: 55%); middle value at least 1.6-fold (0.22 log units) from the limit.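

The steps among compound 1, compound 2 and compound 3 in this assay cannot be read, as all three values are limits of the assay: the limit of > 100000 nM in this assay, at which 3 of the 3 values shown sit.

The compounds shown leave open how far beyond that limit each one lies, and whether any group on the sulfonyl sulfur gives a readable number in this assay.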